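The source may report more compounds than this note shows. Statements on the series, on what has been measured and on what is new or still open speak of the compounds shown alone.

Within the data shown here, in an ADME assay on Caco-2 cells (Homo sapiens) for permeability, in the apical to basolateral direction (a lower number here means that the compound crosses the layer more slowly, a higher number that the compound crosses the layer faster), the three measured members stand as follows. Compound 1 `Cn1cncc1CN1CC(N(CC2CCN(C(=O)CC(C)(C)C)CC2)S(=O)(=O)c2ccccn2)Cc2cc(C#N)ccc21` gives 0.5 10^-6 cm/s. Compound 2 `CC(=O)N1CCC(CN(C2Cc3cc(C#N)ccc3N(Cc3cncn3C)C2)S(=O)(=O)c2ccccn2)CC1` gives 0.5 10^-6 cm/s. Compound 3 `CCOC(=O)N1CCC(CN(C2Cc3cc(C#N)ccc3N(Cc3cncn3C)C2)S(=O)(=O)c2ccccn2)CC1` gives 2.6 10^-6 cm/s, the highest of the three numbers; the steps up to it, a 5.2-fold higher number from compound 1 to compound 3 (0.72 log units; beyond the scatter) and a 5.2-fold higher number from compound 2 to compound 3 (0.72 log units; beyond the scatter), are both beyond the scatter, whereas no change at the digits printed from compound 1 to compound 2 (within the scatter).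

Compound 4 `Cn1cncc1CN1CC(N(CC2CCN(C(=O)CC(F)(F)F)CC2)S(=O)(=O)c2ccccn2)Cc2cc(C#N)ccc21` is not yet measured in this assay. It differs from compound 3 in one place: 2,2,2-trifluoroethyl in place of ethoxy on a carbonyl carbon. The measured steps that bear on this change are the two at the same carbonyl carbon, a 5.2-fold higher number from compound 1 to compound 3 (0.72 log units; beyond the scatter) and a 5.2-fold higher number from compound 2 to compound 3 (0.72 log units; beyond the scatter). In both, ethoxy on the carbonyl carbon goes with the higher number and a carbon group there, neopentyl or methyl, with the lower one. The group entering in compound 4 is again a carbon group, so the nearer comparison is to compound 1 and compound 2, and a modest fall is expected rather than no change. The expected step is a 3.3-fold lower number from compound 3 to compound 4 (0.51 log units; beyond the scatter). Among the measured compounds shown here, compound 4 is therefore estimated at 0.8 10^-6 cm/s, with a range from 0.3 10^-6 cm/s to 2.5 10^-6 cm/s; since no measured compound carries fluorine on that chain, the range is kept wide.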

Compound 4, apparent permeability: 0.5 10^-6 cm/s
For compound 4 the middle estimate is 1.6-fold (0.20 log units) above the measured one; low and high end bracket the measured number.
By their numbers in this assay, from the lowest: compounds 1, 2 and 4 (each within the scatter of the next); then compound 3.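

In this assay the change from ethoxy to 2,2,2-trifluoroethyl on the carbonyl carbon gives a 5.2-fold lower number from compound 3 to compound 4 (0.72 log units; beyond the scatter) and places a third carbon-linked group at this position with the lower numbers. Fluorine on the chain does not set compound 4 apart from the unfluorinated amides: trifluoromethyl in place of hydrogen gives no change at the digits printed from compound 2 to compound 4 (within the scatter) and trifluoromethyl in place of tert-butyl gives no change at the digits printed from compound 1 to compound 4 (within the scatter) for this read-out. Across hydrogen, tert-butyl and trifluoromethyl on the saturated chain carbon bound to the carbonyl carbon no step lies beyond the scatter, and among the four compounds only the ethoxy group of compound 3 stands apart.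

With a single oxygen-linked group in the set, the compounds shown do not tell whether the higher number goes with oxygen on the carbonyl carbon in general or with ethoxy alone. Methoxy, isopropoxy or tert-butoxy at this position would test that, and a dimethylamino group or a longer fluorinated chain there would extend the comparison beyond these two kinds of group.

No measurement at hand offers an explanation for this pattern.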